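Benzoyl to cyano on the sulfonyl-bearing chain carbon

The source may hold more compounds than are shown below. What is called first, only, known or untested is meant among the compounds shown, and "the series" means these compounds.

Three members of the series carry measurements. Compound 1 `COc1ccc(-c2[nH]c3ccccc3c2/C=C(\C#N)S(=O)(=O)c2ccccc2)cc1` gives 404 nM in a functional assay on NCI-H460 cells (Homo sapiens) for inhibition, read by sulforhodamine B assay, with a stated time of 48 h; a lower number here means a stronger inhibitor of growth, a higher number a weaker inhibitor of growth. Compound 2 `CC(=O)/C(=C\c1c(-c2ccccc2)[nH]c2ccccc12)S(=O)(=O)c1ccccc1` gives 1100 nM in this assay, and compound 3 `O=C(/C(=C\c1c(-c2ccccc2)[nH]c2ccccc12)S(=O)(=O)c1ccccc1)c1ccccc1` gives 5900 nM. Compound 3 thus stands highest of the three, weakest as a growth inhibitor, with compound 2 nearest and compound 1 furthest from it. Among the measured compounds shown here, the one single-point step in the set is a 5.4-fold higher number from compound 2 to compound 3 (0.73 log units; beyond the scatter), a change on the carbonyl carbon.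

Compound 4 `N#C/C(=C\c1c(-c2ccccc2)[nH]c2ccccc12)S(=O)(=O)c1ccccc1` is not yet measured. It differs from compound 3 by cyano in place of benzoyl on a double-bonded chain carbon bound to a double-bonded chain carbon and a sulfonyl sulfur. For the measured compounds named here, no measured step matches this change exactly. Compound 1 already carries the cyano group at this chain carbon, but it also differs from compound 4 in the substituent on the aromatic ring at the indole, so the value of compound 1, 404 nM, only shows that a cyano member of the series can sit well below compound 3. Compound 2, with the smaller acetyl group, also sits below compound 3.

On that basis a lower number is expected for compound 4, a step of about a 9.8-fold lower number from compound 3 to compound 4 (0.99 log units; beyond the scatter) from compound 3. The estimate for compound 4 in this assay is 600 nM, with a range from 200 nM to 1800 nM.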

Compound 4, concentration for 50% growth inhibition: 2700 nM
The estimate for compound 4 lay 4.5-fold (0.65 log units) below the measured number, and the stated range ends below it.
By their numbers in this assay, from the lowest: compound 1; then compound 2; then compound 4; then compound 3.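

In this assay, the exchange at this chain carbon now has a direct reading: cyano in place of benzoyl gives a 2.2-fold lower number from compound 3 to compound 4 (0.34 log units; beyond the scatter), a modest gain beyond the scatter. Against acetyl at the same carbon, cyano gives a 2.5-fold higher number from compound 2 to compound 4 (0.39 log units; beyond the scatter), so among the three groups on this shared core, acetyl gives the lowest number, cyano the middle one and benzoyl the highest. The cyano group alone therefore does not account for the low number of compound 1: hydrogen in place of methoxy on an aromatic carbon gives a 6.7-fold higher number from compound 1 to compound 4 (0.82 log units; beyond the scatter), a larger step than the one from benzoyl to cyano.

Nothing at hand accounts for these differences.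

Going by these compounds, it remains open whether a methyl ester or a primary amide at this chain carbon would give a number nearer that of the acetyl compound or that of the benzoyl compound. On these data alone, it is also open whether methoxy on the aromatic carbon would bring a step of similar size alongside acetyl or benzoyl, and whether a hydroxyl or a fluorine there would do the same.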